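The compounds below may be only part of what the source reports. "The series", "measured", "known", "first", "only" and "open" are said of these compounds alone.

Going by the values given here, in an ADME assay on the whole organism (Macaca fascicularis) for pharmacokinetics, with a stated time of 72 h, at a dose of 1 mg/kg by the oral route (on this read-out higher numbers stand for higher exposure at the dose given and lower numbers for lower exposure), compound 1 `Cc1ncncc1-c1nc2cc(F)c(F)cc2n1C1CC1` gives 1260 nM, while compound 2 `Fc1cc2nc(-c3cncnc3C(F)F)n(C3CC3)c2cc1F` gives 620 nM, the lower of the only two numbers so far. Compound 3 `Fc1cc2nc(-c3cncnc3C(F)(F)F)n(C3CC3)c2cc1F` keeps the core of compound 2 and alters one group: fluoro in place of hydrogen on a saturated chain carbon bound to an aromatic carbon and two fluorine atoms. In words, fluoro replaces hydrogen on a saturated chain carbon bound to an aromatic carbon and two fluorine atoms, turning difluoromethyl into trifluoromethyl. Among the compounds with values here, only one measured step bears on this change: a 2.0-fold lower number from compound 1 to compound 2 (0.31 log units; beyond the scatter), a modest drop that came with difluoromethyl in place of methyl on an aromatic carbon. One step is thin evidence, so a small further drop in this assay is expected, and it may not clear the usual scatter. The expected change is a 1.6-fold lower number from compound 2 to compound 3 (0.19 log units; within the scatter). The estimate for compound 3 is 400 nM, with an expected range from 150 nM to 1000 nM.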

Compound 3, maximal plasma concentration: 410 nM
Compound 3: the middle estimate sits 1.0-fold (0.01 log units) below what was measured; low and high end bracket the measured number.
By their numbers in this assay, from the lowest: compounds 3 and 2 (each within the scatter of the next); then compound 1.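

In this assay, turning difluoromethyl into trifluoromethyl gives a 1.5-fold lower number from compound 2 to compound 3 (0.18 log units; within the scatter), so this last fluoro for hydrogen swap does not separate compound 2 from compound 3. The wider comparison is clearer: trifluoromethyl in place of methyl on the aromatic carbon gives a 3.1-fold lower number from compound 1 to compound 3 (0.49 log units; beyond the scatter), a modest step that lies beyond the scatter, so the full change from methyl to trifluoromethyl can be read even though the final single swap cannot. Nothing available explains why exposure differs among these compounds.

The compounds shown carry only methyl and its fluorinated forms at this place, so it remains open how a longer chain such as ethyl, a methoxy group or an amine would fare there. Going by these compounds, whether the same changes would give similar steps on a different core also remains open.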